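Adding a third methyl to a low-potency ester

A few compounds are considered here, and "the series" means these few. Any claim that something is new, unique, unknown or untested is made for them only; others in the source may bear on it.

Two esters of the same core have been tested in a functional assay on the whole organism with Mus musculus as the target; on this read-out lower numbers stand for lower potency and higher numbers for higher potency (the scale is a negative logarithm). Compound 1 `COc1ccccc1C(=O)OC1CCN(C)CC1` gives 1.43, and compound 2 `Cc1cccc(C)c1C(=O)OC1CCN(C)CC1` gives 1.27, a number that lies within the usual scatter of compound 1. Compound 3 `Cc1cc(C)c(C(=O)OC2CCN(C)CC2)c(C)c1` differs from compound 2 by methyl in place of hydrogen on an aromatic carbon. Among the measured compounds shown here, with no measured step to guide the size of the change, the step from compound 2 to compound 3 in this assay is expected to be small, a number 0.07 log units lower from compound 2 to compound 3 (within the scatter), and not clearly beyond the scatter. Compound 3 is therefore estimated at 1.2, within a range of 0.7 to 1.7.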

Compound 3, logarithm of the reciprocal of the active concentration, log(1/C): 1.55
Beside the measured number, compound 3's estimate is 0.35 log units below it, and the stated range covers the measured number.
By their numbers in this assay, from the lowest: compounds 2, 1 and 3 (each within the scatter of the next).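

In this assay, among the compounds shown here, methyl in place of hydrogen on an aromatic carbon, para to a large group, gives a number 0.28 log units higher from compound 2 to compound 3 (within the scatter) and is the first measured step. It shows that this position carries a methyl without a change that stands clear of the scatter. No measurement bears on what lies behind this result.

Still open, as far as these compounds go, is whether an amine, a carboxylic acid or a longer chain at this position would move the number beyond the scatter. This single step also cannot tell whether the same methyl would act alike on the core of compound 1.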